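The source may hold more compounds than are shown below. What is called first, only, known or untested is meant among the compounds shown, and "the series" means these compounds.

Compound 2, `C[Si](C)(C)C#Cc1cc(-c2nc3ccc(F)cc3s2)ccc1N`, gives 400 nM in a functional assay on MDA-MB-468 cells (Homo sapiens) for inhibition, with a stated time of 72 h; on this read-out higher numbers stand for weaker inhibition of growth and lower numbers for stronger inhibition of growth. Of the three compounds measured, compound 2 has the highest number. Compound 1, `N#Cc1cc(-c2nc3ccc(F)cc3s2)ccc1N`, gives 320 nM, and the two lie within the scatter of each other, so neither can be called stronger. Compound 3, `C#Cc1cc(-c2nc3c(F)cccc3s2)ccc1N`, gives 30 nM, a lower number that lies beyond the scatter.

The unmeasured compound 4 is `C#Cc1cc(-c2nc3ccc(F)cc3s2)ccc1N`. Relative to compound 2 the change is a hydrogen atom in place of a group of 4 heavy atoms (3 carbon, 1 silicon; no ring), on a triple-bonded carbon. For the measured compounds named here, only one measured step touches the same place: going from the nitrile to the silicon-bearing group on the aromatic carbon, a 1.3-fold higher number from compound 1 to compound 2 (0.10 log units; within the scatter), made no difference beyond the scatter. Compound 3 carries the same bare triple bond as compound 4, but its fluorine sits differently on the shared core, so its low number cannot be separated into the two changes. Compound 4 is therefore expected to give about 120 nM, somewhere from 30 nM to 450 nM. That expectation amounts to a step of a 3.3-fold lower number from compound 2 to compound 4 (0.52 log units; beyond the scatter).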

Compound 4, concentration for 50% growth inhibition: 23 nM
Compound 4: the middle estimate sits 5.2-fold (0.72 log units) above what was measured; the measured number lies below the stated range.
By their numbers in this assay, from the lowest: compounds 4 and 3 (each within the scatter of the next); then compounds 1 and 2 (each within the scatter of the next).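

In this assay, replacing the group of 4 heavy atoms (3 carbon, 1 silicon) on the triple-bonded carbon with a hydrogen atom gives a large change towards stronger inhibition of growth (a 17-fold lower number from compound 2 to compound 4 (1.24 log units; beyond the scatter)), so what sits at the end of the triple bond matters greatly. Ethynyl in place of cyano on the aromatic carbon also gives a large change (a 14-fold lower number from compound 1 to compound 4 (1.14 log units; beyond the scatter)), whereas the earlier step at this place lay within the scatter and gave no sign that the group there mattered. Nothing available explains either step.

The compounds shown leave open how a small group such as methyl, or a longer chain, would behave on the triple-bonded carbon. They also leave open whether the triple bond itself is needed, which an ethyl group or a chlorine atom on the aromatic carbon could help to test.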